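Changing the Aryl Group: From Compound 1 to Compound 4

The source may hold more compounds than are shown below. What is called first, only, known or untested is meant among the compounds shown, and "the series" means these compounds.

Measured compounds and their values:
- Compound 1, `CCOc1ccc(-c2cc(=O)c3c(o2)C(CC)(CC)C(=O)C(CC)=C3O)cc1`: in a functional assay on KBVIN cells (Homo sapiens) for antiproliferative activity, read by sulforhodamine B assay, with a stated time of 3 days (on this read-out lower numbers stand for an effect already at smaller amounts and higher numbers for an effect only at larger amounts of compound), compound 1 gives 7.54 uM.
- Compound 2, `CCC1=C(O)c2c(oc(-c3cccc(C)c3)cc2=O)C(CC)(CC)C1=O`: compound 2 gives 3.69 uM.
- Compound 3, `CCC1=C(O)c2c(oc(-c3ccc(C)cc3C)cc2=O)C(CC)(CC)C1=O`: compound 3 gives 8.52 uM.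

Among these three numbers compound 1 stands second highest. Its nearest neighbour is reached by a 1.1-fold higher number from compound 1 to compound 3 (0.05 log units; within the scatter), and its furthest by a 2.0-fold lower number from compound 1 to compound 2 (0.31 log units; beyond the scatter).

Compound 4, `CCC1=C(O)c2c(oc(-c3ccc(OC)c(F)c3)cc2=O)C(CC)(CC)C1=O`, differs from compound 1 in one place: 3-fluoro-4-methoxyphenyl in place of 4-ethoxyphenyl on an aromatic carbon.

Both measured steps alter the same aryl group and therefore bear on this change. One, a 2.0-fold lower number from compound 1 to compound 2 (0.31 log units; beyond the scatter), was modest and beyond the scatter; the other, a 1.1-fold higher number from compound 1 to compound 3 (0.05 log units; within the scatter), stayed within it. Neither step introduces a fluorine or keeps an alkoxy group on the ring, so they guide only loosely. The expected outcome is a small shift, a 1.2-fold lower number from compound 1 to compound 4 (0.06 log units; within the scatter), not clearly beyond the scatter.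

Compound 4 is therefore estimated to give 6.5 uM, with a likely range from 3 uM to 14 uM.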

Compound 4, concentration for half-maximal effect: 0.1 uM
For compound 4 the middle estimate is 65-fold (1.81 log units) above the measured one; measured number below the stated range.
By their numbers in this assay, from the lowest: compound 4; then compound 2; then compounds 1 and 3 (each within the scatter of the next).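

The earlier swaps at this aromatic carbon moved the number only modestly, yet in this assay 3-fluoro-4-methoxyphenyl brings a 75-fold lower number from compound 1 to compound 4 (1.88 log units; beyond the scatter) and so shows that this position can change the result far more than those compounds suggested. The effect does not rest on one comparison, since the same group also gives an 85-fold lower number from compound 3 to compound 4 (1.93 log units; beyond the scatter) and a 37-fold lower number from compound 2 to compound 4 (1.57 log units; beyond the scatter) and so stands apart from all three other aryl groups shown. The group that leaves and the group that enters match in heavy atoms and in hydrogen-bond donors and acceptors, and no measurement at hand explains the difference between them.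

The fluorine and the change from ethoxy to methoxy arrive together, so the compounds shown do not tell which of them matters. From the compounds shown here alone, whether 4-methoxyphenyl alone, 3-fluorophenyl alone, or a chlorine or nitrile in place of the fluorine would keep the low number remains open.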